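This account rests on a few compounds, and the source may have more. Where it says the series, first, only, none or still open, it means among the compounds named here.

Series notes. In an in vitro functional assay on cells for agonist activity at Bombesin receptor subtype-3 (Mus musculus), read by luminescence and calcium flux (a higher number here means that more compound is needed for the effect, a lower number that less compound is needed), compound 1 `O=C(O)c1ccccc1-c1ccc(CCc2ncc(C3CCCCC3)[nH]2)cc1` gives 14.7 nM, compound 2 `O=C(O)c1ccccc1-c1ccc(CCc2ncc(CC3CCCC3)[nH]2)cc1` gives 7.9 nM and compound 3 `CC(C)(C)Cc1cnc(CCc2ccc(-c3ccccc3C(=O)O)cc2)[nH]1` gives 6.3 nM. Compound 2 stands second highest of the three numbers; compound 3 is nearest and compound 1 furthest, and both gaps lie within the scatter. Compound 4 `COc1ccccc1Cc1cnc(CCc2ccc(-c3ccccc3C(=O)O)cc2)[nH]1` differs from compound 2 by 2-methoxyphenyl in place of cyclopentyl on a saturated chain carbon bound to an aromatic carbon. Going by the values given here, the only measured step at the same place is a 1.3-fold lower number from compound 2 to compound 3 (0.10 log units; within the scatter), within the scatter; the related steps of a 1.9-fold lower number from compound 1 to compound 2 (0.27 log units; within the scatter) and a 2.3-fold lower number from compound 1 to compound 3 (0.37 log units; beyond the scatter) are also small. Among the compounds with values here, no measured compound carries an aromatic ring or a hydrogen-bond acceptor at this place, so the expectation rests on the narrow spread seen so far: a step of a 1.3-fold higher number from compound 2 to compound 4 (0.10 log units; within the scatter) is expected, not beyond the scatter. Compound 4 is estimated at 10 nM, range 3 nM to 40 nM.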

Compound 4, half-maximal effective concentration: 163 nM
Compound 4: middle estimate off by 16-fold (1.21 log units), on the low side, and the stated range ends below it.
By their numbers in this assay, from the lowest: compounds 3, 2 and 1 (each within the scatter of the next, the first and the last beyond it); then compound 4.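

In this assay, this place proves far less tolerant than the saturated groups suggested: 2-methoxyphenyl in place of cyclopentyl gives a 21-fold higher number from compound 2 to compound 4 (1.31 log units; beyond the scatter), in place of tert-butyl it gives a 26-fold higher number from compound 3 to compound 4 (1.41 log units; beyond the scatter), and 2-methoxybenzyl in place of cyclohexyl gives an 11-fold higher number from compound 1 to compound 4 (1.04 log units; beyond the scatter). Among the saturated groups, the largest change is only a 2.3-fold lower number from compound 1 to compound 3 (0.37 log units; beyond the scatter), so the spread among them did not predict this loss. Nothing available explains the loss.

From the compounds shown here alone, whether it follows from the aromatic ring itself or from the methoxy group remains open. Plain benzyl would separate the two.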